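A few compounds are considered here, and "the series" means these few. Any claim that something is new, unique, unknown or untested is made for them only; others in the source may bear on it.

Three compounds share one core, differing only in the aryl group on the anilino nitrogen. In a functional assay on HGC-27 cells (Homo sapiens) for cytotoxicity, read by MTT assay, with a stated time of 72 h (on this read-out higher numbers stand for weaker inhibition and lower numbers for stronger inhibition), compound 3 `FC(F)(F)c1ccc(CSc2nc(Nc3cccc(Br)c3)c3ccccc3n2)cc1` gives 18300 nM, the lowest of the two numbers shown. Compound 2 `Cc1ccccc1Nc1nc(SCc2ccc(C(F)(F)F)cc2)nc2ccccc12` gives 27500 nM in this assay, and the step of a 1.5-fold lower number from compound 2 to compound 3 (0.18 log units; within the scatter) lies within the scatter. Compound 1 `FC(F)(F)c1ccc(CSc2nc(Nc3ccccc3Cl)c3ccccc3n2)cc1` reports only a limit, > 50000 nM, in this assay (the limit of > 50000 nM in this assay, at which 1 of the 3 values shown sits); from it the steps of an at least 1.8-fold lower number from compound 1 to compound 2 (0.25 log units; that floor lies within the scatter) and an at least 2.7-fold lower number from compound 1 to compound 3 (0.43 log units; beyond the scatter) run toward numbers. Compound 4 `FC(F)(F)c1ccc(CSc2nc(Nc3ccc(C(F)(F)F)cc3)c3ccccc3n2)cc1` carries 4-(trifluoromethyl)phenyl in place of 3-bromophenyl on a nitrogen on an aromatic ring. Every measured step changes this aryl group, and none exceeds a modest size, so compound 4 is expected to move little: an estimated step of a 1.2-fold higher number from compound 3 to compound 4 (0.08 log units; within the scatter). The estimate for compound 4 in this assay is 22000 nM, within 7000 nM to 60000 nM.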

Compound 4, half-maximal inhibitory concentration: 7560 nM
Estimate against measurement, compound 4: 2.9-fold (0.46 log units) above; the range from low to high includes it.
By their numbers in this assay, from the lowest: compound 4; then compounds 3 and 2 (each within the scatter of the next). At a limit, above all of these: compound 1.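

Here 4-(trifluoromethyl)phenyl on the nitrogen gives the first steps between two actual numbers in this assay that lie beyond the scatter: a 2.4-fold lower number from compound 3 to compound 4 (0.38 log units; beyond the scatter) and a 3.6-fold lower number from compound 2 to compound 4 (0.56 log units; beyond the scatter). A further step, an at least 6.6-fold lower number from compound 1 to compound 4 (0.82 log units; beyond the scatter), starts from a limit rather than a number: the limit of > 50000 nM in this assay, at which 1 of the 4 values shown sits. So changing this aryl group can move the number beyond the scatter, though the steps between actual numbers stay modest. The compounds shown leave open whether the step follows the trifluoromethyl group itself or where it sits on the phenyl ring, and whether a nitrile or a carboxylic acid in its stead would lower the number further.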